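A methyl group removed from compound 1

A few compounds are considered here, and "the series" means these few. Any claim that something is new, unique, unknown or untested is made for them only; others in the source may bear on it.

Compound 1 `CO/N=C1/C(=O)N(CCCn2cc(CN3CCC[C@@H]4CN(c5c(F)cc6c(=O)c(C(=O)O)cn(C7CC7)c6c5OC)C[C@@H]43)nn2)c2ccc(C)cc21`: 8 ug/mL
Compound 2 `COc1c(N2C[C@H]3CCCN(Cc4cn(CCCN5C(=O)/C(=N/O)c6cc(C)ccc65)nn4)[C@H]3C2)c(F)cc2c(=O)c(C(=O)O)cn(C3CC3)c12`: 8 ug/mL

Going by the values given here, in an ADME assay on Vero cells (Chlorocebus sabaeus) for cytotoxicity, read by MTT assay, with a stated time of 72 h (on this read-out lower numbers stand for higher toxicity in this test and higher numbers for lower toxicity in this test), compound 1 gives 8 ug/mL and stands level with compound 2 at 8 ug/mL on the numbers so far. Among the compounds with values here, the one measured step is no change at the digits printed from compound 1 to compound 2 (within the scatter) and it is hydrogen in place of methyl on an oxygen, a step within the scatter.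

Compound 3 `CO/N=C1/C(=O)N(CCCn2cc(CN3CCC[C@@H]4CN(c5c(F)cc6c(=O)c(C(=O)O)cn(C7CC7)c6c5OC)C[C@@H]43)nn2)c2ccccc21` departs from compound 1 at another place, with hydrogen in place of methyl on an aromatic carbon of a six-membered aromatic ring of carbon only. Within the data shown here, no measured pair tests this change directly, so the step to compound 2 is only a loose guide.

Going by no change at the digits printed from compound 1 to compound 2 (within the scatter) alone, no step beyond the scatter is expected in this assay and no direction can be favoured. The expected step is no change at the digits printed from compound 1 to compound 3 (within the scatter) in this estimate. For compound 3 the estimated value is 8 ug/mL with an expected range from 4 ug/mL to 18 ug/mL in this test.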

Compound 3, half-maximal cytotoxic concentration: 16 ug/mL
Beside the measured number, compound 3's estimate is 2.0-fold (0.30 log units) below it; the range from low to high includes it.
By their numbers in this assay, from the lowest: compounds 1, 2 and 3 (each within the scatter of the next).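

In this assay, the methyl on an aromatic carbon of the six-membered aromatic ring of carbon only gives way to hydrogen with a 2.0-fold higher number from compound 1 to compound 3 (0.30 log units; within the scatter). This is the first reading at this place, since the earlier pair spoke only to a methyl on an oxygen, and it shows that this aromatic methyl too can be replaced by hydrogen with a step that stays within the scatter, so the methyl is not shown to matter for this read-out at this position. Nothing measured here offers an explanation for the size of this step.

The compounds shown leave open whether another group at this aromatic carbon, such as a chlorine, a methoxy group, a trifluoromethyl group or an amine, would give a step beyond the scatter in this assay. They also leave open what happens when the two single changes are combined, with hydrogen in place of methyl both on the oxygen and on the aromatic carbon of the same compound.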